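Furan regiochemistry on a fluoro and a chloro core

The compounds below may be only part of what the source reports. "The series", "measured", "known", "first", "only" and "open" are said of these compounds alone.

Compound 1 `OC[C@H]1O[C@@H](n2cc(F)c3c(-c4ccco4)ncnc32)[C@H](O)[C@@H]1O` and compound 2 `OC[C@H]1O[C@@H](n2cc(F)c3c(-c4ccoc4)ncnc32)[C@H](O)[C@@H]1O` share one core and differ only in the furan. In an ADME assay on BJ cells (Homo sapiens) for cytotoxicity, read by MTT assay, with a stated time of 72 h (a higher number here means that more compound is tolerated, a lower number that less compound is tolerated), compound 1 gives 310 nM and compound 2 gives 350 nM; the step of a 1.1-fold higher number from compound 1 to compound 2 (0.05 log units; within the scatter) corresponds to the change (furan-3-yl in place of furan-2-yl on an aromatic carbon).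

Compound 3 `OC[C@H]1O[C@@H](n2cc(Cl)c3c(-c4ccco4)ncnc32)[C@H](O)[C@@H]1O` carries a second core, which differs from that of compound 1 by chloro in place of fluoro on an aromatic carbon. In this assay compound 3 gives 37300 nM, a step of a 120-fold higher number from compound 1 to compound 3 (2.08 log units; beyond the scatter).

Compound 4 `OC[C@H]1O[C@@H](n2cc(Cl)c3c(-c4ccoc4)ncnc32)[C@H](O)[C@@H]1O` is not yet measured. It stands to compound 3 as compound 2 stands to compound 1: the change furan-3-yl in place of furan-2-yl on an aromatic carbon is the same change, made on the chloro core rather than the fluoro core. Among the compounds with values here, the only precedent for this change is the step from compound 1 to compound 2, which lay within the scatter. The expected step from compound 3 to compound 4 in this assay is therefore a 1.1-fold higher number from compound 3 to compound 4 (0.03 log units; within the scatter), resting on that single precedent. On this basis compound 4 is estimated at 40000 nM, with a range of 15000 nM to 100000 nM.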

Compound 4, half-maximal cytotoxic concentration: 21600 nM
The estimate for compound 4 lay 1.9-fold (0.27 log units) above the measured number; low and high end bracket the measured number.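

In this assay, the swap to furan-3-yl from furan-2-yl on the chloro core gives a step within the scatter (a 1.7-fold lower number from compound 3 to compound 4 (0.24 log units; within the scatter)), and it carries over from the fluoro core without a difference that can be read: the same change on two cores in this assay, a 1.1-fold higher number (0.05 log units; within the scatter) from compound 1 to compound 2 and a 1.7-fold lower number (0.24 log units; within the scatter) from compound 3 to compound 4, 1.9-fold (0.29 log units) apart, within the scatter of two such steps

The chloro-for-fluoro change stays large on the furan-3-yl series (a 62-fold higher number from compound 2 to compound 4 (1.79 log units; beyond the scatter)), and its size matches that on the furan-2-yl series: the same change on two cores in this assay, a 120-fold higher number (2.08 log units; beyond the scatter) from compound 1 to compound 3 and a 62-fold higher number (1.79 log units; beyond the scatter) from compound 2 to compound 4, 1.9-fold (0.29 log units) apart, within the scatter of two such steps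

Across these four compounds, the halogen therefore sets the level of tolerated compound while the furan regiochemistry leaves it within the scatter, and each change can be carried to the other core in this assay; this rests on one pair of steps per change and does not show that either would transfer to other cores, nor why the halogen step is so large.

Still open, from the compounds shown here alone, is whether a bromo group in place of the chloro extends the halogen step. Also open, going by these compounds, is whether that step survives when an amine or a thiophene ring stands in place of the furan.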